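The source may hold more compounds than are shown below. What is called first, only, known or untested is meant among the compounds shown, and "the series" means these compounds.

Working notes on an assay for binding affinity to Neuropeptide Y receptor type 1 (Homo sapiens), read by radioligand binding; on this read-out higher numbers stand for weaker inhibition and lower numbers for stronger inhibition. Compound 1 `CS(=O)(=O)c1cc(N)c2ncccc2c1[N+](=O)[O-]` returns only a limit in this assay, > 10000 nM. Compound 2 `Nc1ccc(S(=O)(=O)c2ccc3ncccc3c2[N+](=O)[O-])cc1` likewise gives a limit, > 10000 nM. Compound 3 `Cc1cc(S(=O)(=O)c2ccccc2)c([N+](=O)[O-])c2cccnc12` also sits at a limit, > 10000 nM. Within the data shown here, all three values therefore rest at the limit of > 10000 nM in this assay, at which 3 of the 3 values shown sit, so compound 1 stands level with the other two, and no step between measured compounds can be drawn from them. Compound 4 `CCc1ccccc1S(=O)(=O)c1cc(N)c2ncccc2c1[N+](=O)[O-]` is not yet measured; it differs from compound 1 by 2-ethylphenyl in place of methyl on a sulfonyl sulfur. With every measured value at the limit, the size of the step is open. The expected step is an at least 1.4-fold lower number from compound 1 to compound 4 (0.15 log units; that floor lies within the scatter), toward stronger inhibition if any. For compound 4 the expected value is 7000 nM, within 1500 nM to 30000 nM, with a fair chance that this assay again reports only a limit.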

Compound 4, inhibition constant: 129 nM
The estimate for compound 4 lay 54-fold (1.73 log units) above the measured number; measured number outside the range, below it.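

In this assay, the sulfonyl sulfur of the core of compound 1 emerges as a place where the substituent matters: 2-ethylphenyl in place of methyl gives an at least 77-fold lower number from compound 1 to compound 4 (1.88 log units; beyond the scatter). The earlier compounds shown here showed no measurable binding to set against this, and compound 4 alone gives a number rather than a limit: the limit of > 10000 nM in this assay, at which 3 of the 4 values shown sit.

Going by these compounds, the full size of the step remains unknown, since compound 1 supplies only a limit. Also open, on these data alone, is whether the ring alone or the ring with its ethyl group carries the gain, which unsubstituted phenyl or an ethyl chain on the same sulfur would separate.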